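The source may hold more compounds than are shown below. What is called first, only, known or untested is meant among the compounds shown, and "the series" means these compounds.

In a functional assay on SK-BR-3 cells (Homo sapiens) for antiproliferative activity (a lower number here means a stronger inhibitor, a higher number a weaker inhibitor), compound 1 `CC(C)=CCc1cc(C(=O)Nc2cc3ccc(OCC4CCCN(C)C4)c(C)c3oc2=O)ccc1O` gives 1300 nM and compound 2 `CC(C)=CCc1cc(C(=O)Nc2cc3ccc(OCCCN(C(C)C)C(C)C)c(C)c3oc2=O)ccc1O` gives 1600 nM. Between them lies a 1.2-fold higher number from compound 1 to compound 2 (0.09 log units; within the scatter). Compound 3 `CC(C)=CCc1cc(C(=O)Nc2cc3ccc(OCCCNc4ccccc4)c(C)c3oc2=O)ccc1O` stands apart, since it reaches only a limit of the assay, > 50000 nM, and no true number. The anilino group goes with an at least 31-fold higher number from compound 2 to compound 3 (1.49 log units; beyond the scatter), and likewise with an at least 38-fold higher number from compound 1 to compound 3 (1.58 log units; beyond the scatter). Compound 4 `CC(C)=CCc1cc(C(=O)Nc2cc3ccc(OCCCN[C@@H]4C[C@H]5CC[C@@H]4C5)c(C)c3oc2=O)ccc1O` alters that group: a group of 7 heavy atoms (7 carbon; 2 five-membered non-aromatic rings of carbon only) in place of a group of 6 heavy atoms (6 carbon; one six-membered aromatic ring of carbon only), on an amine nitrogen. The phenyl leaves, so the amine nitrogen carries no aromatic ring, as in compound 1 and compound 2. A large step back towards lower numbers in this assay is therefore expected, with an estimated at least 25-fold lower number from compound 3 to compound 4 (1.39 log units; beyond the scatter). Compound 4 is expected at about 2000 nM, with an estimated range of 500 nM to 10000 nM.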

Compound 4, half-maximal inhibitory concentration: 770 nM
The estimate for compound 4 lay 2.6-fold (0.41 log units) above the measured number, within the range that was stated.
By their numbers in this assay, from the lowest: compounds 4, 1 and 2 (each within the scatter of the next, the first and the last beyond it). At a limit, above all of these: compound 3.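

In this assay, putting the group with 2 five-membered non-aromatic rings of carbon only in place of the phenyl on the amine nitrogen gives an at least 64-fold lower number from compound 3 to compound 4 (1.81 log units; beyond the scatter), so an amine nitrogen that keeps its hydrogen, as in compound 3, need not show the loss seen there. This step is only a lower bound, since compound 3 stands at a limit: the limit of > 50000 nM in this assay, at which 1 of the 4 values shown sits. Against the earlier amines, the steps are small: a 2.1-fold lower number from compound 2 to compound 4 (0.32 log units; beyond the scatter), and a 1.7-fold lower number from compound 1 to compound 4 (0.23 log units; within the scatter).

Going by these compounds, it remains open whether the loss goes with the aromatic ring as such or with any six-membered ring. A cyclohexyl group on that amine nitrogen would tell these apart.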